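Taking the bromo off compound 3

This account rests on a few compounds, and the source may have more. Where it says the series, first, only, none or still open, it means among the compounds named here.

In an ADME assay on HEK-293T cells (Homo sapiens) for cytotoxicity, read by luminescence and CellTiter-Glo, with a stated time of 24 h (on this read-out lower numbers stand for higher toxicity in this test and higher numbers for lower toxicity in this test), compound 3, `CCCNC(=O)C1CCN(C(=O)c2cc3cc(Br)ccc3n2Cc2ccc(OC)cc2)CC1`, gives > 100000 nM, which is a limit and not a number. Compound 2, `CCCNC(=O)[C@@H]1[C@@H]2CCC[C@H]1CN(C(=O)c1cc3sc(Br)cc3n1Cc1ccc(OC)cc1)C2`, gives > 100000 nM, and this too is a limit. Compound 3 therefore stands at the limit of > 100000 nM in this assay, at which 2 of the 3 values shown sit. Only compound 1, `CCCNC(=O)C1CCN(C(=O)c2cc3ncsc3n2Cc2ccc(OC)cc2)CC1`, gives a true number, 42700 nM.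

Compound 4, `CCCNC(=O)C1CCN(C(=O)c2cc3ccccc3n2Cc2ccc(OC)cc2)CC1`, differs from compound 3 in a single place: hydrogen in place of bromo on an aromatic carbon, with hydrogen in place of bromo on an aromatic carbon. Within the data shown here, compound 3 offers only a limit as a starting point, and no measured pair of compounds differing in one place shows how large such a step can be. In this assay, the expectation is a small step towards lower numbers, possibly none beyond the usual scatter. Compound 1 at 42700 nM shows that a true number can be read in this series. The expected change is an at least 1.2-fold lower number from compound 3 to compound 4 (0.09 log units; that floor lies within the scatter). The estimate for compound 4 is 80000 nM, with an expected range from 35000 nM to 150000 nM.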

Compound 4, half-maximal cytotoxic concentration: 26000 nM
Compound 4: middle estimate off by 3.1-fold (0.49 log units), on the high side; the whole stated range lies above it.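

In this assay, putting hydrogen in place of bromo on an aromatic carbon gives an at least 3.8-fold lower number from compound 3 to compound 4 (0.58 log units; beyond the scatter), so the group at this position of the six-membered aromatic ring of carbon only does matter in this test. Compound 4 also replaces the limit seen for compound 3 with a true number, giving the only measured size for a one-place step here. That size is still a minimum, and the real step may be larger, because compound 3 carries only a limit: the limit of > 100000 nM in this assay, at which 2 of the 4 values shown sit.

The compounds shown leave open how other groups at this position would read, such as chloro, nitrile or an amine. They also leave open whether the same change would have a similar effect on the core of compound 2, whose value is also a limit.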